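From trifluoromethoxy to trifluoromethyl on compound 3

A few compounds are considered here, and "the series" means these few. Any claim that something is new, unique, unknown or untested is made for them only; others in the source may bear on it.

- compound 1 `O=S(=O)(NCCCN1CCCCc2ccccc21)c1ccc(OC(F)(F)F)cc1` gives "not active" (no number reported) (no number)
- compound 2 `O=S(=O)(NCCCN1CCCCc2ccccc21)c1ccc(Cl)cc1` gives "not active" (no number reported) (no number)
- compound 3 `O=S(=O)(NC1CCC2(OC1)c1ccccc1CCc1ccccc12)c1ccc(OC(F)(F)F)cc1` gives 13000 nM (the only number)

These results come from a functional assay on NCI-H1650 cells (Homo sapiens) for inhibition, read by MTT assay, with a stated time of 48 h (on this read-out lower numbers stand for stronger inhibition of growth and higher numbers for weaker inhibition of growth), and leave compound 3 with nothing numerical to be ranked against. Compound 4 `O=S(=O)(NC1CCC2(OC1)c1ccccc1CCc1ccccc12)c1ccc(C(F)(F)F)cc1` keeps the core of compound 3 and carries trifluoromethyl in place of trifluoromethoxy on an aromatic carbon, para to a large group (trifluoromethyl in place of trifluoromethoxy on an aromatic carbon). Among the compounds with values here, no measured pair shows this change, so the expectation rests on compound 3 alone, at 13000 nM and nothing more. In this assay no change beyond the scatter is expected, in either direction, and the estimated no change at the digits printed from compound 3 to compound 4 (within the scatter) follows that view. A result without a number also remains possible. The estimated value for compound 4 is 13000 nM (expected range 5000 nM to 35000 nM).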

Compound 4, concentration for 50% growth inhibition: 15000 nM
Beside the measured number, compound 4's estimate is 1.2-fold (0.06 log units) below it; the range from low to high includes it.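

In this assay, trifluoromethyl in place of trifluoromethoxy on an aromatic carbon, para to a large group, gives a 1.2-fold higher number from compound 3 to compound 4 (0.06 log units; within the scatter), so on this core the oxygen atom can go without a shift beyond the scatter. Within the data shown here, this is the first step that can be read at this position, since compound 1 and compound 2 give no number. Nothing measured explains why the two groups give such similar values.

Going by these compounds, whether an amine or a carboxylic acid at this position on the shared core would move the number remains open.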